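The source may report more compounds than this note shows. Statements on the series, on what has been measured and on what is new or still open speak of the compounds shown alone.

Of the compounds shown here, two have been measured so far. Compound 1 `CCC/N=C1\S/C(=C\c2ccc(O)c(Br)c2)C(=O)N1c1ccccc1C` carries a bromine on its phenol ring and a methyl-bearing aromatic ring on the amide-type nitrogen of the shared core; in a physicochemical assay for lipophilicity, read by HPLC, at pH 7.4 (on this read-out lower numbers stand for lower lipophilicity and higher numbers for higher lipophilicity), compound 1 gives 3.9. Compound 2 `CCC/N=C1\S/C(=C\c2ccc(O)c(Cl)c2)C(=O)N1C1CCOCC1` carries a chlorine instead and an oxan-4-yl group on that nitrogen; in this assay compound 2 gives 3.7. That is the lower of the two numbers, but the gap to compound 1 lies within the usual scatter, so the two cannot be ranked against each other. Compound 3 `CCC/N=C1\S/C(=C\c2ccc(O)c(Cl)c2)C(=O)N1C1CCS(=O)(=O)CC1` has not yet been measured. It differs from compound 2 in one place: 1,1-dioxothian-4-yl in place of oxan-4-yl on an amide-type nitrogen in a ring. Going by the values given here, no measured pair shows this change, so the expectation rests on the change itself. The step expected in this assay is a number 1.10 log units lower from compound 2 to compound 3 (beyond the scatter), downward and beyond the scatter. Compound 3 is therefore estimated at 2.6, within a range from 2.1 to 3.1.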

Compound 3, distribution coefficient: 2.6
Compound 3: the middle estimate sits on the measured number at the digits printed; measured number inside the range.
By their numbers in this assay, from the lowest: compound 3; then compounds 2 and 1 (each within the scatter of the next).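

Replacing oxan-4-yl with 1,1-dioxothian-4-yl on the amide-type nitrogen gives, in this assay, a number 1.10 log units lower from compound 2 to compound 3 (beyond the scatter), the first effect of a single change that can be read, as compound 1 and compound 2 differ in two places. The read-out therefore responds to this position even though the ring stays six-membered and non-aromatic with one hetero atom; the entering group adds sulfur and raises the count of hydrogen-bond acceptors from 1 to 2. Nothing measured here shows which of these differences accounts for the step.

This single pair leaves open whether the same step would appear with the bromine-bearing phenol ring of compound 1. Also open, from the compounds shown here alone, is what a piperidine ring with its amine, or an open chain ending in a carboxylic acid, would give at this position.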